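Compound 1 to compound 4: a larger group enters

The source may report more compounds than this note shows. Statements on the series, on what has been measured and on what is new or still open speak of the compounds shown alone.

Compound 1 `COc1cc(OC)c(/C=C/S(=O)(=O)Nc2ccc(OC)c(OP(=O)(O)O)c2)c(OC)c1` holds the lowest number of the three measured in a functional assay on K562 cells (Homo sapiens) for cytotoxicity, read by trypan blue exclusion, with a stated time of 96 h (on this read-out higher numbers stand for weaker inhibition and lower numbers for stronger inhibition), giving 7.5 nM. Compound 3 `COc1ccc(NS(=O)(=O)/C=C/c2c(OC)cc(OCCCC(=O)O)cc2OC)cc1O` stands nearest, with 10000 nM in this assay, and compound 2 `COc1ccc(NS(=O)(=O)/C=C/c2cc(OC)c(OC)c(OC)c2)cc1N` stands furthest, with 15000 nM; both gaps lie beyond the scatter. Compound 4 `COc1cc(OC)c(/C=C/S(=O)(=O)Nc2ccc(OC)c(NC(C(=O)O)c3ccccc3)c2)c(OC)c1` is not yet measured. It differs from compound 1 in one place: a group of 11 heavy atoms (8 carbon, 1 nitrogen, 2 oxygen; one six-membered aromatic ring of carbon only) in place of a group of 5 heavy atoms (4 oxygen, 1 phosphorus; no ring), on an aromatic carbon. For the measured compounds named here, no step between measured compounds covers this change, so the expectation rests on the three numbers alone. Compound 2 gives 15000 nM with a plain amino group on the shared core, and that is the closest guide. On that basis a step toward higher numbers, well beyond the scatter, is expected: a 270-fold higher number from compound 1 to compound 4 (2.43 log units; beyond the scatter). Compound 4 is estimated at 2000 nM, within a range of 200 nM to 20000 nM.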

Compound 4, half-maximal inhibitory concentration: 300 nM
Beside the measured number, compound 4's estimate is 6.7-fold (0.82 log units) above it; low and high end bracket the measured number.
By their numbers in this assay, from the lowest: compound 1; then compound 4; then compounds 3 and 2 (each within the scatter of the next).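

In this assay, the (carboxy(phenyl)methyl)amino group in place of the phosphorus-bearing group, on the aromatic carbon ortho to a methoxy group, gives a 40-fold higher number from compound 1 to compound 4 (1.60 log units; beyond the scatter). Both groups count the same hydrogen-bond donors and acceptors and no net charge, so these counts do not separate compound 1 from compound 4. Nothing at hand accounts for the size of this step.

Which part of the entering group goes with the step remains open. A methyl ester in place of the carboxylic acid, or an aminoacetic acid group without the phenyl ring, would separate the two parts at this position.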